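Ring substituent changes in the dienone series: compound 4

The source may hold more compounds than are shown below. What is called first, only, known or untested is meant among the compounds shown, and "the series" means these compounds.

Going by the values given here, three compounds share one core and differ only in the single group on the aromatic ring. In a functional assay on PC-3 cells (Homo sapiens) for cytotoxicity, read by sulforhodamine B assay, with a stated time of 48 h (a lower number here means a stronger inhibitor, a higher number a weaker inhibitor), compound 3 `CC1=C(/C=C/C(=O)/C=C/c2ccc(C)cc2)C(C)(C)CCC1` gives 21500 nM, the highest of the three numbers. Compound 1 `CC1=C(/C=C/C(=O)/C=C/c2ccc(Br)cc2)C(C)(C)CCC1` gives 18900 nM, and compound 2 `CC1=C(/C=C/C(=O)/C=C/c2ccc(F)cc2)C(C)(C)CCC1` gives 8200 nM. Compound 3 lies within the scatter of compound 1 and apart only from compound 2: a 1.1-fold higher number from compound 1 to compound 3 (0.06 log units; within the scatter) and a 2.6-fold higher number from compound 2 to compound 3 (0.42 log units; beyond the scatter), while a 2.3-fold lower number from compound 1 to compound 2 (0.36 log units; beyond the scatter). All three exchanges of the ring group are thus modest or within the scatter.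

Compound 4 `CC1=C(/C=C/C(=O)/C=C/c2ccc([N+](=O)[O-])cc2)C(C)(C)CCC1` is the next exchange at the same place: nitro in place of methyl on an aromatic carbon. Among the compounds with values here, no measured step brings in a nitro group, so no direct precedent exists; the only guidance is that every exchange of this ring group so far has moved the number little. On that basis a small step is expected in this assay, a 1.4-fold lower number from compound 3 to compound 4 (0.16 log units; within the scatter), with no clear direction. Compound 4 is therefore estimated at 15000 nM, with a range from 6000 nM to 40000 nM.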

Compound 4, half-maximal inhibitory concentration: 1900 nM
Compound 4: the middle estimate sits 7.9-fold (0.90 log units) above what was measured; measured number below the stated range.
By their numbers in this assay, from the lowest: compound 4; then compound 2; then compounds 1 and 3 (each within the scatter of the next).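

Compound 4 shows that this ring position is not as flat in this assay as the bromo, fluoro and methyl compounds suggested: the exchange for nitro gives an 11-fold lower number from compound 3 to compound 4 (1.05 log units; beyond the scatter) and a 9.9-fold lower number from compound 1 to compound 4 (1.00 log units; beyond the scatter) as well as a 4.3-fold lower number from compound 2 to compound 4 (0.64 log units; beyond the scatter) and so makes compound 4 the strongest of the four. The largest earlier exchange at this place was only a 2.6-fold higher number from compound 2 to compound 3 (0.42 log units; beyond the scatter) so the identity of the group matters more here than those three compounds could show. No supporting data are available to explain why the nitro group stands apart from the other three groups.

On these data alone, it remains open whether the low number is particular to the nitro group or is shared by other groups here, such as a nitrile, an amine or a carboxylic acid. As far as these compounds go, it also remains open whether the nitro group would give a similar number at another place on the aromatic ring.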